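Hydroxamic acid series: trimming one naphthylmethyl from the amine

A few compounds are considered here, and "the series" means these few. Any claim that something is new, unique, unknown or untested is made for them only; others in the source may bear on it.

Measured compounds
- compound 1 `O=C(CCCCCCN(Cc1ccc2ccccc2c1)Cc1ccc2ccccc2c1)NO`: 5400 nM
- compound 2 `O=C(CCCCCCNCc1ccc(-c2ccccc2)s1)NO`: 550 nM
- compound 3 `O=C(CCCCCCN(Cc1cc2ccccc2[nH]1)Cc1cc2ccccc2[nH]1)NO`: 4600 nM

In an assay on cells for inhibition of histone deacetylase 8 (Homo sapiens), read by fluorescence, with a stated time of 24 h (on this read-out higher numbers stand for weaker inhibition and lower numbers for stronger inhibition), compound 1 gives 5400 nM, the highest number of the three. Compound 3 sits nearest, at 4600 nM, a gap that falls within the scatter, so the two cannot be placed in order. Compound 2 is the furthest away, at 550 nM, and that gap lies beyond the scatter. Compound 2 differs from compound 1 in more than one place, so the two values show only that the set spans a wide window.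

Compound 4 `O=C(CCCCCCNCc1ccc2ccccc2c1)NO` has not been measured in this assay. It differs from compound 1 in one place: hydrogen in place of (naphthalen-2-yl)methyl on an amine nitrogen. After the change the amine nitrogen carries hydrogen, as in compound 2. Among the measured compounds, compound 2 is the only one with hydrogen on the amine nitrogen, and in this assay compound 2 gives 550 nM; the two compounds with two arylmethyl groups on the nitrogen, compound 1 and compound 3, give the two higher numbers. On that basis a step toward a lower number is expected, of the size a 6.0-fold lower number from compound 1 to compound 4 (0.78 log units; beyond the scatter), beyond the scatter, though compound 2 also carries a different aryl group and so cannot fix the size. For compound 4 the estimate is 900 nM, with a range from 300 nM to 2700 nM.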

Compound 4, half-maximal inhibitory concentration: 320 nM
Compound 4: the middle estimate sits 2.8-fold (0.45 log units) above what was measured; the measured number falls inside the stated range.
By their numbers in this assay, from the lowest: compounds 4 and 2 (each within the scatter of the next); then compounds 3 and 1 (each within the scatter of the next).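

In this assay, going by these compounds alone, hydrogen in place of (naphthalen-2-yl)methyl on the amine nitrogen gives a 17-fold lower number from compound 1 to compound 4 (1.23 log units; beyond the scatter), the first step that can be read at a single place. The second arylmethyl group on this nitrogen is therefore not needed for a low number in this pair: the change removes 11 heavy atoms and two six-membered aromatic rings, and the number falls rather than rises. No supporting measurement bears on why the number changes at this position.

The compounds shown leave open whether the low number depends on hydrogen itself on the nitrogen or only on the absence of the second (naphthalen-2-yl)methyl, a question that a methyl, an ethyl or a benzyl group at this place would address. Going by these compounds, it is also open whether the same replacement on compound 3 would give a step of similar size, and whether a longer or shorter chain would change the result for compound 4.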